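The source may report more compounds than this note shows. Statements on the series, on what has been measured and on what is new or still open speak of the compounds shown alone.

Three compounds share one core and differ only in the ester. Compound 1 `COC(=O)C1=C(C)N(C)C(=O)NC1c1ccoc1` gives 7% in an assay on membranes from HeLa cells for displacement of a labelled ligand from adenosine receptor A3 (Homo sapiens), read by scintillation counting, with a stated time of 180 min, tested at 1 uM; a higher number here means more inhibition at the concentration tested (going by the name of the read-out), a lower number less inhibition. Compound 2 `CCCOC(=O)C1=C(C)N(C)C(=O)NC1c1ccoc1` gives 16% in this assay, and compound 3 `CC1=C(C(=O)OC(C)(C)C)C(c2ccoc2)NC(=O)N1C` gives 12%. Compound 3 stands second of the three numbers, with compound 2 closest, a number 4 percentage points lower from compound 2 to compound 3 (within the scatter), and compound 1 furthest, a number 5 percentage points higher from compound 1 to compound 3 (within the scatter). Compound 4 `CC1=C(C(=O)OC(C)(C)C)C(c2cccs2)NC(=O)N1C` has not yet been measured. It differs from compound 3 as follows: thiophen-2-yl in place of furan-3-yl on a saturated ring carbon. Within the data shown here, none of the measured steps concerns the group on the saturated ring carbon; they concern the ester only, and all of them were small: a number 9 percentage points higher from compound 1 to compound 2 (within the scatter), a number 5 percentage points higher from compound 1 to compound 3 (within the scatter) and a number 4 percentage points lower from compound 2 to compound 3 (within the scatter). Nothing in these numbers tells how the change to a thiophen-2-yl group would move the inhibition. The estimate for compound 4 therefore expects no step beyond the scatter, no change at the digits printed from compound 3 to compound 4 (within the scatter), and a value of 12%, with a range from 0% to 30%.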

Compound 4, a percentage reported as inhibition, at one concentration (the size of the read-out at that concentration, not a potency): 22%
The estimate for compound 4 lay 10 percentage points below the measured number; measured number inside the range.
By their numbers in this assay, from the lowest: compounds 1, 3, 2 and 4 (each within the scatter of the next, the first and the last beyond it).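

Among these compounds, at the saturated ring carbon the earlier compounds offered no step at all, and the exchange of furan-3-yl for thiophen-2-yl now gives the first one in this assay, a number 10 percentage points higher from compound 3 to compound 4 (within the scatter). This shows that, on the tert-butoxycarbonyl compounds, swapping one five-membered aromatic ring with one hetero atom for the other moves the number no further than the scatter, as the ester changes also did. Nothing measured on these compounds bears on why the number moved as it did.

From the compounds shown here alone, with a single step at this position, it stays open whether the same exchange would read alike with the methyl or propyl ester. Going by these compounds, it also stays open what a phenyl ring, or a ring carrying an amine or a carboxylic acid, would do on the saturated ring carbon.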